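Aminotriazolyl thioamides: chain hydroxylation step

This account rests on a few compounds, and the source may have more. Where it says the series, first, only, none or still open, it means among the compounds named here.

Measured so far:
compound 1 `CCCC/N=C(\S)n1ncnc1N` — 21%
compound 2 `Nc1ncnn1/C(S)=N/Cc1ccccc1` — 40%

In a functional assay on the whole organism for inhibition, with Rattus norvegicus as the target, at a dose of 30 mg/kg (on this read-out higher numbers stand for more inhibition at the one dose given (going by the name of the read-out) and lower numbers for less inhibition), compound 1 gives 21% and stands lowest of the two numbers; the nearest value, that of compound 2 in this assay at 40%, lies higher by an amount beyond the scatter. Among the measured compounds shown here, no step between compounds differing in one place is available, so the pair says only what its two values show.

Compound 3 `Nc1ncnn1/C(S)=N/CCCCCO` is not yet measured in this assay. It differs from compound 1 by hydroxymethyl in place of hydrogen on a saturated chain carbon, four bonds along the chain from a double-bonded nitrogen. For the measured compounds named here, with no measured pair of this kind, the size and direction of the step cannot be read from the series. The step from compound 1 to compound 3 in this assay is expected to be small, a number 4 percentage points higher from compound 1 to compound 3 (within the scatter), and not clearly beyond the scatter in either direction. Compound 3 is therefore estimated at 25% in this assay, with a range from 5% to 45%.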

Compound 3, a percentage reported as inhibition, in the whole organism at one dose (the size of the read-out at that dose, not a potency): -17%
Estimate against measurement, compound 3: 42 percentage points above, outside the stated range (below it).
By their numbers in this assay, from the lowest: compound 3; then compound 1; then compound 2.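

In this assay, hydroxymethyl in place of hydrogen on a saturated chain carbon, four bonds along the chain from a double-bonded nitrogen, gives a number 38 percentage points lower from compound 1 to compound 3 (beyond the scatter) on the shared core. Among the compounds shown here, this is the first single-place change, and it shows that the read-out responds strongly to a change at this chain carbon. The change also takes the number below zero, with compound 3 at -17% in this assay on a scale where higher numbers stand for more inhibition. No measurement in hand accounts for this step.

Going by these compounds, whether the step follows the oxygen or the added carbon stays open, since a longer chain without oxygen would be needed to separate them. On these data alone, an amine or a carboxylic acid in place of the hydroxymethyl is equally open.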